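Replacing a Dimethoxyphenyl Group on a Bis(trifluoromethyl)benzenesulfonamide

The compounds below may be only part of what the source reports. "The series", "measured", "known", "first", "only" and "open" are said of these compounds alone.

Three compounds have so far been measured in a functional assay on MCF7 cells (Homo sapiens) for inhibition, read by MTT assay, with a stated time of 72 h; on this read-out higher numbers stand for weaker inhibition of growth and lower numbers for stronger inhibition of growth:

Compound 1, `COc1ccc(CNCCCNS(=O)(=O)c2cc(C(F)(F)F)cc(C(F)(F)F)c2)cc1OC`, gives 1900 nM.
Compound 2, `O=S(=O)(NCCCNCc1ccc(C(F)(F)F)cc1)c1cc(C(F)(F)F)cc(C(F)(F)F)c1`, gives 1400 nM.
Compound 3, `O=S(=O)(NCCCNCc1ccc(Cl)cc1)c1cc(C(F)(F)F)cc(C(F)(F)F)c1`, gives 2400 nM.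

Compound 1 holds the second-highest of the three numbers. Its neighbours lie close on either side: a 1.3-fold higher number from compound 1 to compound 3 (0.10 log units; within the scatter), and a 1.4-fold lower number from compound 1 to compound 2 (0.13 log units; within the scatter). The remaining pair is likewise close, since a 1.7-fold higher number from compound 2 to compound 3 (0.23 log units; within the scatter). All three compounds therefore sit within the usual scatter of one another.

Compound 4, `COc1ccccc1CNCCCNS(=O)(=O)c1cc(C(F)(F)F)cc(C(F)(F)F)c1`, has not yet been measured. It differs from compound 1 by 2-methoxyphenyl in place of 3,4-dimethoxyphenyl on a saturated chain carbon bound to an amine nitrogen. The two measured steps that bear on this change are those from compound 1 to compound 2 and from compound 1 to compound 3, both of which exchange the same group at the same place and both of which stayed within the scatter. Nothing in the data shows that the group on the saturated chain carbon bound to the amine nitrogen moves the number in this assay beyond the scatter. Compound 4 is therefore expected to give about 1900 nM in this assay, within a range from 900 nM to 4000 nM. That estimate corresponds to an expected no change at the digits printed from compound 1 to compound 4 (within the scatter), that is, no change beyond the scatter.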

Compound 4, concentration for 50% growth inhibition: 2600 nM
For compound 4 the middle estimate is 1.4-fold (0.14 log units) below the measured one; low and high end bracket the measured number.
By their numbers in this assay, from the lowest: compounds 2, 1, 3 and 4 (each within the scatter of the next).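

With 2-methoxyphenyl, this assay now covers a group that keeps a methoxy substituent but gives up the 3,4-dimethoxy arrangement, and this change on a saturated chain carbon bound to an amine nitrogen gives a 1.4-fold higher number from compound 1 to compound 4 (0.14 log units; within the scatter), which stays within the scatter. The new group also remains within the scatter of the other two groups, with a 1.1-fold higher number from compound 3 to compound 4 (0.03 log units; within the scatter) against 4-chlorophenyl and a 1.9-fold higher number from compound 2 to compound 4 (0.27 log units; within the scatter) against 4-(trifluoromethyl)phenyl. The earlier compounds shown here showed this flat picture only for groups named with a substituent at 4, whereas it now also holds for a group named with its only substituent at 2, so no compound among the four stands apart from the others at this position.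

Going by these compounds, whether the number stays this flat for a phenyl group carrying a carboxylic acid or an amine, or for a longer chain in place of the present saturated chain, remains open in these compounds. No measurement shown here bears on why these four groups give such similar numbers.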